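The compounds below may be only part of what the source reports. "The series", "measured", "known", "first", "only" and "open" are said of these compounds alone.

Values so far in a functional assay on HCT-116 cells (Homo sapiens) for inhibition, read by CCK-8 assay, with a stated time of 48 h (a higher number here means a weaker inhibitor, a lower number a stronger inhibitor), for the series:

Compound 1 `COc1cc(-c2ccnc3cc(-c4ccccc4)nn23)cc(OC)c1OC` gives 3880 nM
Compound 2 `C=Cc1ccc(-c2cc3nccc(-c4cc(OC)c(OC)c(OC)c4)n3n2)cc1` gives 1060 nM

Compound 2 holds the lower of the two numbers, 1060 nM in this assay for now. Next is compound 3 `COc1ccc(-c2cc3nccc(-c4cc(OC)c(OC)c(OC)c4)n3n2)cc1F`, which differs from compound 2 as follows: 3-fluoro-4-methoxyphenyl in place of 4-vinylphenyl on an aromatic carbon. Within the data shown here, only one measured step bears on this change: a 3.7-fold lower number from compound 1 to compound 2 (0.56 log units; beyond the scatter), modest and beyond the scatter, with vinyl in place of hydrogen on an aromatic carbon. As far as these compounds go, compound 3 carries no vinyl, so a modest move back towards a higher number is expected, though its 3-fluoro-4-methoxyphenyl group remains untested. The expected step is a 1.7-fold higher number from compound 2 to compound 3 (0.23 log units; within the scatter) in this estimate. Compound 3 is estimated at 1800 nM with 600 nM to 5000 nM as the expected range.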

Compound 3, half-maximal inhibitory concentration: 2840 nM
Beside the measured number, compound 3's estimate is 1.6-fold (0.20 log units) below it; the range from low to high includes it.
By their numbers in this assay, from the lowest: compound 2; then compounds 3 and 1 (each within the scatter of the next).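

At this aromatic carbon of the five-membered ring, 3-fluoro-4-methoxyphenyl does not keep the result of 4-vinylphenyl, giving a 2.7-fold higher number from compound 2 to compound 3 (0.43 log units; beyond the scatter). Against plain phenyl, the same group gives a 1.4-fold lower number from compound 1 to compound 3 (0.14 log units; within the scatter), so among these three aryl groups only 4-vinylphenyl stands apart. Nothing available explains this difference.

Open, as far as these compounds go, is how fluoro and methoxy each act alone on the phenyl ring, since they enter together here. Also open, from the compounds shown here alone, is how an amine or a carboxylic acid on that ring would compare with vinyl.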